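The compounds below may be only part of what the source reports. "The series", "measured", "known", "first", "only" and "open" are said of these compounds alone.

- compound 1 `Nc1cc(=O)[nH]c(=O)n1[C@@H]1O[C@H](CO)[C@@H](O)[C@H]1O`: > 50000 nM
- compound 2 `CNc1cc(=O)[nH]c(=O)n1[C@@H]1O[C@H](CO)[C@@H](O)[C@H]1O`: > 50000 nM
- compound 3 `O=Cc1cc(=O)[nH]c(=O)n1[C@@H]1O[C@H](CO)[C@@H](O)[C@H]1O`: > 50000 nM

These three entries come from a functional assay on OCI-Ly7 cells (Homo sapiens) for antiproliferative activity, read by WST assay, with a stated time of 3 days (a lower number here means a stronger inhibitor, a higher number a weaker inhibitor), and each is a limit, not a number. Compound 1 gives > 50000 nM, so its position is known only as a limit. Overall, the data show (the limit of > 50000 nM in this assay, at which 3 of the 3 values shown sit).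

Compound 4 `Nc1c(F)c(=O)[nH]c(=O)n1[C@@H]1O[C@H](CO)[C@@H](O)[C@H]1O` keeps the core of compound 1 with one change: fluoro in place of hydrogen on an aromatic carbon.

Within the data shown here, three measured steps bear on it: a step that the two limits leave unreadable from compound 1 to compound 2, a step that the two limits leave unreadable from compound 1 to compound 3 and a step that the two limits leave unreadable from compound 2 to compound 3. None has a readable size, and none introduces fluoro, so they give only weak guidance. Compound 4 is therefore expected to remain weak in this assay, quite possibly at the same limit, with any shift toward stronger inhibition.

The expected change is an at least 1.2-fold lower number from compound 1 to compound 4 (0.09 log units; that floor lies within the scatter).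

For compound 4 the estimated value is 40000 nM, with an expected range of 4000 nM to 100000 nM.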

Compound 4, half-maximal inhibitory concentration: 1300 nM
Beside the measured number, compound 4's estimate is 31-fold (1.49 log units) above it; measured number below the stated range.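

In this assay, fluoro in place of hydrogen on an aromatic carbon, ortho to an amino group, gives an at least 38-fold lower number from compound 1 to compound 4 (1.58 log units; beyond the scatter). Among these compounds, this single added atom turns a compound with no readable activity into the only compound here with a true number rather than a limit. The steps among compound 1, compound 2 and compound 3 cannot be read, and those three share one limit: the limit of > 50000 nM in this assay, at which 3 of the 4 values shown sit.

From the compounds shown here alone, whether chloro, bromo or methyl on this aromatic carbon would have a similar effect stays open. So does whether fluoro would give the same gain alongside the methylamino group of compound 2.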